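The source may hold more compounds than are shown below. What is called first, only, known or untested is meant among the compounds shown, and "the series" means these compounds.

Compound 1 `NCc1ccc(CN(Cc2nc3ccccc3[nH]2)C2CCCc3cccnc32)c(CN)c1` gives 10 nM in a functional assay on CEM-CCRF cells for antagonist activity at C-X-C chemokine receptor type 4 (Homo sapiens), read by calcium flux; on this read-out lower numbers stand for stronger inhibition and higher numbers for weaker inhibition.
Compound 2 `NCc1ccoc1CN(Cc1nc2ccccc2[nH]1)C1CCCc2cccnc21` gives 12 nM in this assay.

Among the compounds with values here, compound 2 holds the higher of the two numbers so far, but the step of a 1.2-fold higher number from compound 1 to compound 2 (0.08 log units; within the scatter) lies within the scatter, so on these two numbers compound 1 and compound 2 cannot be told apart.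

Compound 3 `NCc1occc1CN(Cc1nc2ccccc2[nH]1)C1CCCc2cccnc21` is the next candidate. It differs from compound 2 by a group of 7 heavy atoms (5 carbon, 1 nitrogen, 1 oxygen; one five-membered aromatic ring with 1 hetero atom) in place of a group of 7 heavy atoms (5 carbon, 1 nitrogen, 1 oxygen; one five-membered aromatic ring with 1 hetero atom), on a saturated chain carbon bound to an amine nitrogen; the two compounds share the same atoms, joined differently, so the change is a rearrangement of the five-membered ring rather than an exchange of one group for another.

Within the data shown here, only one measured step bears on this change. The replacement of the six-membered ring of compound 1 by the five-membered ring of compound 2 gave a 1.2-fold higher number from compound 1 to compound 2 (0.08 log units; within the scatter), a step within the scatter. Among the measured compounds shown here, no measured pair shows what moving the groups around the five-membered ring does. Given that this assay hardly moved across the one comparable step, the step of a 1.3-fold higher number from compound 2 to compound 3 (0.10 log units; within the scatter) is expected to stay within the scatter, in no particular direction. Compound 3 is therefore estimated at 15 nM, with a range from 5 nM to 45 nM.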

Compound 3, half-maximal inhibitory concentration: 21 nM
Estimate against measurement, compound 3: 1.4-fold (0.15 log units) below; the range from low to high includes it.
By their numbers in this assay, from the lowest: compounds 1, 2 and 3 (each within the scatter of the next, the first and the last beyond it).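

Moving the groups around the five-membered aromatic ring, on a saturated chain carbon bound to an amine nitrogen, gives a 1.8-fold higher number from compound 2 to compound 3 (0.24 log units; within the scatter) in this assay, so the two arrangements of the same atoms cannot be told apart on this read-out. Within the data shown here, the change from the six-membered aromatic ring of carbon only now gives a 2.1-fold higher number from compound 1 to compound 3 (0.32 log units; beyond the scatter), the first step at this position to pass beyond the scatter, although it is a modest one, while the other five-membered arrangement still gives a 1.2-fold higher number from compound 1 to compound 2 (0.08 log units; within the scatter); the ring exchange can therefore cost a little in this assay, but only one of the two arrangements shows this. Nothing available bears on why the arrangements compare in this way.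

The compounds shown leave open how this position would respond to a five-membered aromatic ring with sulfur in place of oxygen, to a longer chain carrying the amine, or to an amide in place of the amine. Among these compounds, they also leave open whether the modest step seen here would hold on a core other than the one shared by these compounds.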